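Ethylamino to dimethylamino on the amide side chain

A few compounds are considered here, and "the series" means these few. Any claim that something is new, unique, unknown or untested is made for them only; others in the source may bear on it.

compound 1 `COc1ccc(C(=O)c2ccc(OC)c3c2C=CC(C)(C)O3)c(NC(=O)CO)c1`: 420 nM
compound 2 `COc1ccc(C(=O)c2ccc(OC)c3c2C=CC(C)(C)O3)c(NC(=O)CN)c1`: 890 nM
compound 3 `CCNCC(=O)Nc1cc(OC)ccc1C(=O)c1ccc(OC)c2c1C=CC(C)(C)O2`: 4090 nM

In a functional assay on A2780 cells (Homo sapiens) for antiproliferative activity, read by MTT assay, with a stated time of 48 h (on this read-out lower numbers stand for stronger inhibition and higher numbers for weaker inhibition), compound 3 gives 4090 nM, the highest number of the three. The series shows a 2.1-fold higher number from compound 1 to compound 2 (0.33 log units; beyond the scatter), then a 4.6-fold higher number from compound 2 to compound 3 (0.66 log units; beyond the scatter), and overall a 9.7-fold higher number from compound 1 to compound 3 (0.99 log units; beyond the scatter).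

Compound 4 `COc1ccc(C(=O)c2ccc(OC)c3c2C=CC(C)(C)O3)c(NC(=O)CN(C)C)c1` keeps the shared core and has the same atoms as compound 3, joined differently: dimethylamino in place of ethylamino on a saturated chain carbon bound to a carbonyl carbon. In words, dimethylamino stands in place of ethylamino on a saturated chain carbon bound to a carbonyl carbon.

Going by the values given here, the closest precedent is a 4.6-fold higher number from compound 2 to compound 3 (0.66 log units; beyond the scatter), where ethyl replaces hydrogen on an amine nitrogen. Among the compounds with values here, no measured compound carries dimethylamino, so this step bears on the change only indirectly. Compound 4 also has the two carbons on the nitrogen that compound 3 has, so a shift as large as that precedent is not expected. A modest move toward a lower number is expected, and no change beyond the scatter remains possible.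

The estimated change is a 1.6-fold lower number from compound 3 to compound 4 (0.21 log units; within the scatter).

For compound 4 the expected value is 2500 nM, with an estimated range of 800 nM to 7000 nM.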

Compound 4, half-maximal inhibitory concentration: 3990 nM
For compound 4 the middle estimate is 1.6-fold (0.20 log units) below the measured one; the range from low to high includes it.
By their numbers in this assay, from the lowest: compound 1; then compound 2; then compounds 4 and 3 (each within the scatter of the next).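

In this assay, the two ways of placing the same atoms on the saturated chain carbon bound to a carbonyl carbon do not separate: a 1.0-fold lower number from compound 3 to compound 4 (0.01 log units; within the scatter). Ethylamino has a hydrogen-bond donor and dimethylamino has none, yet this difference goes with no readable change in this pair. Dimethylamino instead stays well away from the amino and hydroxy compounds, with a 4.5-fold higher number from compound 2 to compound 4 (0.65 log units; beyond the scatter) and a 9.5-fold higher number from compound 1 to compound 4 (0.98 log units; beyond the scatter), so in these four compounds the presence of the two carbons on the nitrogen tracks with the higher numbers, whichever way they are arranged.

Nothing available accounts for these steps. On these data alone, whether a morpholine ring or a carboxylic acid at this place would stay with compound 4 or move toward compound 1 remains open.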